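A few compounds are considered here, and "the series" means these few. Any claim that something is new, unique, unknown or untested is made for them only; others in the source may bear on it.

Measured so far:
compound 1 `O=C1NC(=O)/C(=C/C(c2ccc(-c3ccc4cccc(F)c4c3)[nH]c2=O)C2CCCCC2)O1`: 8 nM
compound 2 `CC(C)[C@H](C[C@H]1OC(=O)NC1=O)c1ccc(-c2ccc3cccc(F)c3c2)[nH]c1=O`: 15 nM
compound 3 `CC(C)[C@@H](c1ccc(-c2ccc3cccc(F)c3c2)[nH]c1=O)[C@H]1OC(=O)NC1=O`: 92 nM

In a functional assay on CHO cells for antagonist activity at prostaglandin E2 receptor EP3 subtype (Homo sapiens), read by cAMP accumulation, with a stated time of 30 min (a lower number here means a stronger inhibitor, a higher number a weaker inhibitor), compound 3 gives 92 nM, the highest of the three numbers. Its nearest neighbour is compound 2 with 15 nM, and compound 1 with 8 nM lies furthest away. Among the compounds with values here, only one measured step touches the site of interest: a 6.1-fold higher number from compound 2 to compound 3 (0.79 log units; beyond the scatter), a modest loss that still lies beyond the scatter.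

Compound 4 `CC(C)[C@H](C[C@@H]1OC(=O)NC1=O)c1ccc(-c2ccc3cccc(F)c3c2)[nH]c1=O` differs from compound 3 by (2,4-dioxo-1,3-oxazolidin-5-yl)methyl in place of 2,4-dioxo-1,3-oxazolidin-5-yl on a saturated chain carbon bound to an aromatic carbon and a saturated chain carbon. In the length of the link this reverses the step from compound 2 to compound 3, so the expectation from that step alone is a lower number in this assay. Within the data shown here, compound 4 is, however, not identical to compound 2: the configuration at the stereocentre within the (2,4-dioxo-1,3-oxazolidin-5-yl)methyl group is the opposite one, and no measured pair shows what that inversion does. The reversal is therefore expected to be recovered only in part, with a wide range to cover the unknown stereochemical contribution.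

For compound 4 the estimated step is a 3.1-fold lower number from compound 3 to compound 4 (0.49 log units; beyond the scatter), giving an expected value of 30 nM, with a range from 8 nM to 120 nM.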

Compound 4, half-maximal inhibitory concentration in the prostaglandin E2 receptor EP3 subtype assay: 27 nM
Compound 4: the middle estimate sits 1.1-fold (0.05 log units) above what was measured, within the range that was stated.
By their numbers in the prostaglandin E2 receptor EP3 subtype assay, from the lowest: compounds 1, 2 and 4 (each within the scatter of the next, the first and the last beyond it); then compound 3.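

In the prostaglandin E2 receptor EP3 subtype assay compound 2 gives 15 nM and compound 4 gives 27 nM; inverting the ring stereocentre of the (2,4-dioxo-1,3-oxazolidin-5-yl)methyl group amounts to a 1.8-fold higher number from compound 2 to compound 4 (0.26 log units; within the scatter), so at this position the configuration of that ring carbon has no effect that can be told from the scatter, and this pair reads as a test of configuration alone: the fact that compounds 2 and 4 differ only in the configuration as drawn. In the prostaglandin E2 receptor EP3 subtype assay the lower number with the (2,4-dioxo-1,3-oxazolidin-5-yl)methyl group therefore holds for both ring configurations, with a 3.4-fold lower number from compound 3 to compound 4 (0.53 log units; beyond the scatter) alongside the earlier 6.1-fold higher number from compound 2 to compound 3 (0.79 log units; beyond the scatter). In a physicochemical assay for solubility, in phosphate buffer, measured as kinetic solubility (on this read-out higher numbers stand for higher solubility and lower numbers for lower solubility), compound 3 gives 31600 nM and compound 4 gives 21100 nM, the same change amounting to a 1.5-fold lower number from compound 3 to compound 4 (0.18 log units; within the scatter), so the improvement in the prostaglandin E2 receptor EP3 subtype assay comes without a solubility difference beyond the scatter.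

Still open, as far as these compounds go, is whether a longer chain carrying the 2,4-dioxo-1,3-oxazolidin-5-yl ring would keep or extend the improvement seen with the (2,4-dioxo-1,3-oxazolidin-5-yl)methyl group. The compounds shown also leave open whether a carboxylic acid could stand in place of the ring at this saturated chain carbon, and what the opposite ring configuration does when the 2,4-dioxo-1,3-oxazolidin-5-yl group is attached directly.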